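This account rests on a few compounds, and the source may have more. Where it says the series, first, only, none or still open, it means among the compounds named here.

In a functional assay on HepG2 cells (Homo sapiens) for antiproliferative activity, read by MTT assay, with a stated time of 48 h (a lower number here means a stronger inhibitor, a higher number a weaker inhibitor), compound 1 `Clc1cccc(Nc2ncnc3ccc(NCc4cccc(Br)n4)cc23)c1` gives 3870 nM as its value, compound 2 `Clc1cccc(Nc2ncnc3ccc(NCc4ncc5ccccc5n4)cc23)c1` gives 5650 nM and compound 3 `Clc1cccc(Nc2ncnc3ccc(NCc4ccc(Br)s4)cc23)c1` gives 3110 nM on the same read-out. Compound 2 cannot be separated from either of the others, with a 1.5-fold higher number from compound 1 to compound 2 (0.16 log units; within the scatter) on one side and a 1.8-fold lower number from compound 2 to compound 3 (0.26 log units; within the scatter) on the other. The change followed here leads to compound 4 `Cc1cccc(CNc2ccc3ncnc(Nc4cccc(Cl)c4)c3c2)n1` and puts 6-methylpyridin-2-yl in place of quinazolin-2-yl on a saturated chain carbon bound to a nitrogen on an aromatic ring in the structure. All three measured swaps sit at that same place, the third being a 1.2-fold lower number from compound 1 to compound 3 (0.09 log units; within the scatter) and none of them leaving the scatter. Compound 1 carries 6-bromopyridin-2-yl, the measured group closest in name to the entering one. On these steps, no change beyond the scatter is expected in this assay for this swap. The expected step is a 1.4-fold lower number from compound 2 to compound 4 (0.15 log units; within the scatter) and it remains an estimate. For compound 4 the estimated value is 4000 nM with 2000 nM to 8000 nM as the expected range.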

Compound 4, half-maximal inhibitory concentration: 3630 nM
For compound 4 the middle estimate is 1.1-fold (0.04 log units) above the measured one, and the stated range covers the measured number.
By their numbers in this assay, from the lowest: compounds 3, 4, 1 and 2 (each within the scatter of the next).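

In this assay, among the compounds shown here, the swap of methyl for bromo on an aromatic carbon (a 1.1-fold lower number from compound 1 to compound 4 (0.03 log units; within the scatter)) changes only the substituent, whereas the earlier steps at this place each replaced a whole group. The whole-group steps to compound 4 also stay within the scatter (a 1.6-fold lower number from compound 2 to compound 4 (0.19 log units; within the scatter); a 1.2-fold higher number from compound 3 to compound 4 (0.07 log units; within the scatter)), so in these compounds neither bromo nor the all-carbon aromatic ring of quinazolin-2-yl, with 10 heavy atoms against 7 in 6-methylpyridin-2-yl, separates the numbers. No measured evidence bears on why these steps are so small.

From the compounds shown here alone, all four compounds carry an aromatic ring on the saturated chain carbon, so the reading for a non-aromatic group such as morpholine or a carboxylic acid stays open. Also open, going by these compounds, is whether any group at this place moves the number beyond the scatter.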